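Adding Chloro to a Fluorophenyl Amide Under Cell Toxicity

The source may report more compounds than this note shows. Statements on the series, on what has been measured and on what is new or still open speak of the compounds shown alone.

Measured in a toxicity assay on Vero cells (Chlorocebus sabaeus) for inhibition, read by MTT assay, with a stated time of 48 h; a lower number here means a stronger inhibitor, a higher number a weaker inhibitor:
Compound 1, `O=C(N/N=C/c1c(-c2cc3ccc(Br)cc3oc2=O)[nH]c2ccccc12)c1ccccc1`, gives > 200000 nM, which is a limit of the assay.
Compound 2, `O=C(N/N=C/c1c(-c2cc3ccc(Br)cc3oc2=O)[nH]c2ccccc12)c1ccccc1F`, gives > 200000 nM, also a limit of the assay.

Compound 2 therefore stands at the limit in this assay; (the limit of > 200000 nM in this assay, at which 2 of the 2 values shown sit). Compound 3, `O=C(N/N=C/c1c(-c2cc3ccc(Br)cc3oc2=O)[nH]c2ccccc12)c1ccc(Cl)cc1F`, differs from compound 2 by chloro in place of hydrogen on an aromatic carbon. Going by the values given here, the only measured step, a step that the two limits leave unreadable from compound 1 to compound 2, is unreadable in size, so nothing measured shows what a chloro does here. The expected step is a step that the limit leaves unreadable from compound 2 to compound 3, most likely ending at the limit again. Compound 3 is estimated at 300000 nM in this assay, within a range from 100000 nM to 1000000 nM.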

Compound 3, half-maximal inhibitory concentration: < 25000 nM
Compound 3 ended at the assay's limit; the forecaster's own chance of this, stated with the estimate: 80%; middle value at least 12-fold (1.07 log units) away from the limit.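

In this assay, the chloro gives an at least 8.0-fold lower number from compound 2 to compound 3 (0.90 log units; beyond the scatter), the first readable change among these compounds, so this position on the ring can alter toxicity to the cells. Replacing phenyl with 4-chloro-2-fluorophenyl gives an at least 8.0-fold lower number from compound 1 to compound 3 (0.90 log units; beyond the scatter). Both steps rest on limits and so give only a minimum size, while the step from compound 1 to compound 2 cannot be read.

Going by these compounds, whether the chloro would have the same effect without the fluoro stays open. So does what an amine or a carboxylic acid would do at the same place.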